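This account rests on a few compounds, and the source may have more. Where it says the series, first, only, none or still open, it means among the compounds named here.

Three compounds of the series have numbers in a functional assay on HT-1080 cells (Homo sapiens) for antiproliferative activity, read by sulforhodamine B assay, with a stated time of 48 h (on this read-out higher numbers stand for weaker inhibition and lower numbers for stronger inhibition), so far: compound 1 `CCCC(=O)Nc1cccc(S(=O)(=O)Oc2ccccc2C(C)C)c1`, compound 2 `CC(C)C(=O)Nc1ccc(S(=O)(=O)Oc2ccccc2C(C)C)cc1` and compound 3 `CC(C)C(=O)Nc1ccc(S(=O)(=O)Oc2ccccc2I)cc1`. In this assay compound 2 gives 4900 nM, the second highest of the three; compound 3 gives 3300 nM, which differs by a 1.5-fold lower number from compound 2 to compound 3 (0.17 log units; within the scatter), and compound 1 gives 15000 nM, a higher number beyond the scatter. The next compound, compound 4 `CCCCCNC(=O)Nc1ccc(S(=O)(=O)Oc2ccccc2C(C)C)cc1`, differs from compound 2 by pentylamino in place of isopropyl on a carbonyl carbon. Within the data shown here, no measured step touches the group on that carbonyl carbon; the one step on record, from compound 2 to compound 3, concerns the other aromatic ring and stays within the scatter, so no firm direction follows. Compound 4 is therefore expected near the number of compound 2, a step of a 1.1-fold lower number from compound 2 to compound 4 (0.04 log units; within the scatter), estimated at 4500 nM with a range of 1300 nM to 15000 nM.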

Compound 4, half-maximal inhibitory concentration: 4700 nM
For compound 4 the middle estimate is 1.0-fold (0.02 log units) below the measured one; the range from low to high includes it.
By their numbers in this assay, from the lowest: compounds 3, 4 and 2 (each within the scatter of the next); then compound 1.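

In this assay, among these compounds, pentylamino in place of isopropyl on a carbonyl carbon gives a 1.0-fold lower number from compound 2 to compound 4 (0.02 log units; within the scatter), the first measured step at this position. The longer chain and added nitrogen thus move the number by no more than the scatter, so (pentylcarbamoyl)amino and (isopropylcarbonyl)amino cannot be told apart here. No supporting data on this change are at hand. From the compounds shown here alone, whether a terminal amine or carboxylic acid on this chain would shift the number remains open. Also open, going by these compounds, is how pentylamino reads when combined with iodo in place of isopropyl on an aromatic carbon.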